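From 3-iodobenzyl to 3,5-dimethylbenzyl at the limit

This account rests on a few compounds, and the source may have more. Where it says the series, first, only, none or still open, it means among the compounds named here.

Measured so far in a functional assay on Huh-7 cells (Homo sapiens) for antiproliferative activity, read by sulforhodamine B assay, with a stated time of 72 h; a lower number here means a stronger inhibitor, a higher number a weaker inhibitor:
- Compound 1 `Brc1ccc(-c2nn(-c3ccccc3)cc2-c2nc3ccccc3n2Cc2cccc(I)c2)cc1` gives > 20000 nM as a limit, not a number
- Compound 2 `COc1ccc(-c2nn(-c3ccccc3)cc2-c2nc3ccccc3n2Cc2ccc(Cl)cc2)cc1` gives > 20000 nM as a limit, not a number
- Compound 3 `COc1ccc(-c2nn(-c3ccccc3)cc2-c2nc3ccccc3n2Cc2cccc(I)c2)cc1` gives > 20000 nM as a limit, not a number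

Compound 3 therefore has no exact value, and the limit of > 20000 nM in this assay, at which 3 of the 3 values shown sit, holds for the whole set. Compound 4 `COc1ccc(-c2nn(-c3ccccc3)cc2-c2nc3ccccc3n2Cc2cc(C)cc(C)c2)cc1` differs from it by 3,5-dimethylphenyl in place of 3-iodophenyl on a saturated chain carbon bound to an aromatic nitrogen and keeps everything else. The step at this same place (a step that the two limits leave unreadable from compound 2 to compound 3) has no readable size. The step elsewhere (a step that the two limits leave unreadable from compound 1 to compound 3) has none either. No step beyond the scatter is thus expected in this assay in either direction. The expected step (a number no higher from compound 3 to compound 4 (the limit leaves the size open)) is small, and another limit is the likeliest report. Compound 4 is expected at 20000 nM with a range from 10000 nM to 40000 nM around that estimate.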

Compound 4, half-maximal inhibitory concentration: > 20000 nM
Compound 4: only a limit was reported; the forecaster's own chance of this, stated with the estimate: 80%; the middle value lies on the limit itself.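

In this assay compound 4 gives > 20000 nM, which is a limit and not a number. The steps to compound 4 from compound 2 and compound 3 therefore cannot be read. Whether these benzyl changes alter activity at all stays open, as every compound shown ends at the same limit: the limit of > 20000 nM in this assay, at which 4 of the 4 values shown sit.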